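A few compounds are considered here, and "the series" means these few. Any claim that something is new, unique, unknown or untested is made for them only; others in the source may bear on it.

Three compounds share one core and differ only in the group on the outer six-membered ring of carbon only. Compound 1 `O=C(/C=C/c1ccc2c(c1)B(O)OC2)c1ccc(Cl)cc1` gives 3700 nM in a functional assay on SK-OV-3 cells (Homo sapiens) for cytotoxicity, read by MTT assay, with a stated time of 48 h; a higher number here means a weaker inhibitor, a lower number a stronger inhibitor. Compound 2 `CSc1ccc(C(=O)/C=C/c2ccc3c(c2)B(O)OC3)cc1` gives 4100 nM in this assay, and the step of a 1.1-fold higher number from compound 1 to compound 2 (0.04 log units; within the scatter) is within the scatter. Compound 3 `O=C(/C=C/c1ccc2c(c1)B(O)OC2)c1ccc(O)cc1` gives 13000 nM in this assay, the highest of the three numbers; the steps of a 3.5-fold higher number from compound 1 to compound 3 (0.55 log units; beyond the scatter) and a 3.2-fold higher number from compound 2 to compound 3 (0.50 log units; beyond the scatter) are both beyond the scatter, so compound 3 is the weakest inhibitor among the three measured.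

Compound 4 `O=C(/C=C/c1ccc2c(c1)B(O)OC2)c1ccc([N+](=O)[O-])cc1` differs from compound 3 in one place: nitro in place of hydroxy on an aromatic carbon. The two measured steps that bear on it are the ones that lead to the hydroxy group, a 3.5-fold higher number from compound 1 to compound 3 (0.55 log units; beyond the scatter) and a 3.2-fold higher number from compound 2 to compound 3 (0.50 log units; beyond the scatter), each modest and each a higher number on arrival at hydroxy. For the measured compounds named here, neither of them involves a nitro group, so what is known is only that the two groups other than hydroxy gave lower numbers than hydroxy. On that basis a modest step to a lower number is expected, of a size near those two steps reversed, which is written as an expected step of a 2.6-fold lower number from compound 3 to compound 4 (0.41 log units; beyond the scatter). For compound 4 the estimated value in this assay is therefore 5000 nM, with a range from 2000 nM to 14000 nM.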

Compound 4, half-maximal inhibitory concentration: 7900 nM
The estimate for compound 4 lay 1.6-fold (0.20 log units) below the measured number, within the range that was stated.
By their numbers in this assay, from the lowest: compounds 1, 2, 4 and 3 (each within the scatter of the next, the first and the last beyond it).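

In this assay, the hydroxy group of compound 3 gives way to a nitro group with no hydrogen-bond donor, yet a 1.6-fold lower number from compound 3 to compound 4 (0.22 log units; within the scatter) does not separate the two, so having no donor on this aromatic carbon does not by itself place a compound with chloro and apart from hydroxy. Nitro also stands within the scatter of methylsulfanyl, as a 1.9-fold higher number from compound 2 to compound 4 (0.28 log units; within the scatter) shows, while a 2.1-fold higher number from compound 1 to compound 4 (0.33 log units; beyond the scatter) is the only one of its three steps that goes beyond it, so the clear separation between hydroxy and the two earlier groups gives way to an overlapping series in which only the chloro compound stands clear of nitro. No measured property of these compounds is available to account for these differences.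

The compounds shown leave open how an amine, a carboxylic acid or a methoxy group on this same aromatic carbon would compare with these four groups. They also leave open whether any group at this place can give a number clearly lower than that of compound 1, as none of the others does.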